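Swapping a halogenated benzyl group on two piperidinone cores

This account rests on a few compounds, and the source may have more. Where it says the series, first, only, none or still open, it means among the compounds named here.

Four compounds are described here, built on two different cores. Compound 1 `O=C1/C(=C/c2ccccc2F)CN(Cc2cn(Cc3ccccc3F)nn2)C/C1=C\c1ccccc1F` and compound 2 `O=C1/C(=C/c2ccccc2F)CN(Cc2cn(Cc3cccc(Cl)c3)nn2)C/C1=C\c1ccccc1F` share one core, and compound 3 `Cc1ccc(/C=C2\CN(C(=S)SCc3cn(Cc4cccc(Cl)c4)nn3)C/C(=C\c3ccc(C)cc3)C2=O)cc1` and compound 4 `Cc1ccc(/C=C2\CN(C(=S)SCc3cn(Cc4ccccc4F)nn3)C/C(=C\c3ccc(C)cc3)C2=O)cc1` share another; the difference between the two cores is not broken down here. In a functional assay on MDA-MB-231 cells (Homo sapiens) for cytotoxicity, read by MTT assay, with a stated time of 24 h (on this read-out higher numbers stand for weaker inhibition and lower numbers for stronger inhibition), compound 2 gives 12000 nM, and compound 1 gives 16000 nM. The change between them is 2-fluorophenyl in place of 3-chlorophenyl on a saturated chain carbon bound to an aromatic nitrogen, and it produced a 1.3-fold higher number from compound 2 to compound 1 (0.12 log units; within the scatter), a step too small to separate the two compounds. Compound 3 gives 83000 nM in this assay, the highest of the three measured numbers, with the gaps to compound 1 and compound 2 both beyond the usual scatter.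

Compound 4 is not yet measured. Among the compounds with values here, it differs from compound 3 by 2-fluorophenyl in place of 3-chlorophenyl on a saturated chain carbon bound to an aromatic nitrogen, which is the same change as the one from compound 2 to compound 1, made at the same kind of position on the other core. Within the data shown here, since the only measured example of this swap, the step of a 1.3-fold higher number from compound 2 to compound 1 (0.12 log units; within the scatter), stayed within the scatter, the expected step here is a 1.1-fold higher number from compound 3 to compound 4 (0.06 log units; within the scatter), with the value for compound 4 remaining close to that of compound 3. The estimate for compound 4 in this assay is 95000 nM, with a plausible range from 40000 nM to 220000 nM. This expectation rests on a single measured pair, compound 2 and compound 1, and the cores differ in ways not resolved here. The range is kept wide.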

Compound 4, half-maximal inhibitory concentration: 91500 nM
Estimate against measurement, compound 4: 1.0-fold (0.02 log units) above; the range from low to high includes it.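

In this assay, putting the 2-fluorobenzyl group in place of the 3-chlorobenzyl group on the second core gives a 1.1-fold higher number from compound 3 to compound 4 (0.04 log units; within the scatter), so the two numbers cannot be told apart. The same swap on the first core was just as small, and the two steps agree: the same change on two cores in this assay, a 1.3-fold higher number (0.12 log units; within the scatter) from compound 2 to compound 1 and a 1.1-fold higher number (0.04 log units; within the scatter) from compound 3 to compound 4, 1.2-fold (0.08 log units) apart, within the scatter of two such steps. This shows that, on both cores shown, the swap makes no difference that this cell assay can detect, so the earlier result carried over to the second core; it does not show that the two groups are interchangeable in general, since both steps are too small to separate from repeat-to-repeat noise and two pairs say nothing about other cores.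

The compounds shown also leave open whether anything other than a halogenated benzyl group would move the number at this position, for example a benzyl group carrying an amine or a carboxylic acid, or a longer chain between the ring and the aromatic nitrogen. Within the data shown here, the two cores differ in more than one place, and no pair of compounds here isolates a single part of that difference, so its contribution to the numbers remains unresolved.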